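This account rests on a few compounds, and the source may have more. Where it says the series, first, only, none or still open, it means among the compounds named here.

Compound 3 `CC(=O)OCc1cc(C(C)(C)C)ccc1C/N=C(\S)NCc1ccc(NS(C)(=O)=O)cc1` gives 580 nM in a functional assay for inhibition of Vanilloid receptor (Rattus norvegicus) (on this read-out higher numbers stand for weaker inhibition and lower numbers for stronger inhibition), the highest of the three numbers recorded. Compound 2 `COCOc1cc(C(C)(C)C)ccc1C/N=C(\S)NCc1ccc(NS(C)(=O)=O)cc1` gives 500 nM in this assay, and compound 1 `CCCOc1cc(C(C)(C)C)ccc1C/N=C(\S)NCc1ccc(NS(C)(=O)=O)cc1` gives 250 nM. The step from compound 1 to compound 3 reads a 2.3-fold higher number from compound 1 to compound 3 (0.37 log units; beyond the scatter), while the step from compound 2 to compound 3 reads a 1.2-fold higher number from compound 2 to compound 3 (0.06 log units; within the scatter). Compound 4 `CC(C)(C)C(=O)OCc1cc(C(C)(C)C)ccc1C/N=C(\S)NCc1ccc(NS(C)(=O)=O)cc1` differs from compound 3 by a single change: tert-butyl in place of methyl on a carbonyl carbon. Going by the values given here, none of the measured steps touches the acyl part of the ester; the two steps that reach compound 3 each replace the whole group on the aromatic carbon, so they bear on compound 4 only indirectly, by showing that the acetoxymethyl variant sits close to the methoxymethoxy one. On this basis no step beyond the scatter is expected, and the estimated step from compound 3 to compound 4 is a 1.2-fold higher number from compound 3 to compound 4 (0.08 log units; within the scatter). Compound 4 is therefore expected to give about 700 nM in this assay, within a range from 300 nM to 1600 nM.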

Compound 4, half-maximal inhibitory concentration: 70 nM
Estimate against measurement, compound 4: 10-fold (1.00 log units) above; the whole stated range lies above it.
By their numbers in this assay, from the lowest: compound 4; then compounds 1, 2 and 3 (each within the scatter of the next, the first and the last beyond it).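

Going by these compounds alone, the acyl part of the ester, which no earlier step touched, proves to be a sensitive place: in this assay, tert-butyl in place of methyl on the carbonyl carbon gives an 8.3-fold lower number from compound 3 to compound 4 (0.92 log units; beyond the scatter) and so outweighs every difference seen among the earlier compounds. The (((tert-butyl)carbonyl)oxy)methyl group also clears both other groups on the aromatic carbon, with a 7.1-fold lower number from compound 2 to compound 4 (0.85 log units; beyond the scatter) and a 3.6-fold lower number from compound 1 to compound 4 (0.55 log units; beyond the scatter), so compound 4 is the strongest inhibitor of the four, whereas the acetoxymethyl group of compound 3 had fallen behind the propoxy group of compound 1. Nothing shown here explains this change.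

Going by these compounds, it remains open whether the shift belongs to tert-butyl itself or would also appear with ethyl, isopropyl or cyclopropyl on the carbonyl carbon. On these data alone, it is equally open whether an amide in place of the ester would keep it.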